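The source may report more compounds than this note shows. Statements on the series, on what has been measured and on what is new or still open speak of the compounds shown alone.

Compound 3 `O=S(=O)(Nc1ccc(-c2nc3ccccc3o2)cc1)c1ccccc1O` sits at a limit of an assay on isolated protein for inhibition of malate dehydrogenase, mitochondrial (Sus scrofa), with stated times of 45 min and 30 min (a lower number here means a stronger inhibitor, a higher number a weaker inhibitor), rather than at a number: in this assay compound 3 gives > 63000 nM. Compound 1 `O=S(=O)(Nc1ccc(-c2nc3ccccc3o2)cc1)c1cccc(F)c1` also gives only a limit, > 63000 nM, in this assay. Compound 2 `Cc1ccc(S(=O)(=O)Nc2ccc(-c3nc4ccccc4o3)cc2)cc1` likewise gives only a limit, > 63000 nM, in this assay. Where compound 3 stands among them is therefore not readable, since all three values sit at the limit of > 63000 nM in this assay, at which 3 of the 3 values shown sit.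

Compound 4 `O=S(=O)(Nc1ccc(-c2nc3ccccc3o2)cc1)c1ccc(O)cc1` differs from compound 3 in one place: 4-hydroxyphenyl in place of 2-hydroxyphenyl on a sulfonyl sulfur. The measured steps that bear on this change of a sulfonyl substituent are a step that the two limits leave unreadable from compound 1 to compound 2, a step that the two limits leave unreadable from compound 1 to compound 3 and a step that the two limits leave unreadable from compound 2 to compound 3, and none of them gives a readable size. Among the compounds with values here, the change from compound 3 to compound 4 therefore offers no step against which to expect a gain or a loss, and the expected step that the limit leaves unreadable from compound 3 to compound 4 from compound 3 to compound 4 is none beyond the scatter. For compound 4 the estimate in this assay is 100000 nM, with a range from 40000 nM to 300000 nM, and it is expected most likely to return a limit again.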

Compound 4, half-maximal inhibitory concentration: > 63000 nM
Compound 4 gave a limit, no number (the forecaster's own chance of this, stated with the estimate: 85%); the middle value lies beyond the limit too.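

The steps from compound 1, compound 2 and compound 3 to compound 4 cannot be read, since compound 4 also gives only a limit in this assay: the limit of > 63000 nM in this assay, at which 4 of the 4 values shown sit.

The compounds shown leave open whether any sulfonyl substituent on the shared core gives a measurable value in this assay, and how far these four compounds differ.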